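This account rests on a few compounds, and the source may have more. Where it says the series, first, only, none or still open, it means among the compounds named here.

Measured so far:
compound 1 `N/C(=N\NC(=S)N1CCCC1)c1ccccn1` — 84.5%
compound 2 `Cc1ccnc(/C(N)=N/NC(=S)N2CCCCC2)c1` — 69.1%

In a functional assay on HeLa cells (Homo sapiens) for cytotoxicity, read by MTT assay, with a stated time of 72 h, tested at 30 uM (a higher number here means more inhibition of growth at the concentration tested, a lower number less inhibition of growth), compound 1 gives 84.5% and compound 2 gives 69.1%. Compound 2 thus stands lowest of the two numbers, and its gap to compound 1 lies beyond the scatter. Going by the values given here, compound 1 and compound 2 differ in two places at once, so no single step connects them; their two values show only that compound 1 reads higher, without telling which of the two changes carries the difference.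

Compound 3 `Cc1ccnc(/C(N)=N/NC(=S)N2CCCC2)c1` has not yet been measured in this assay. It carries pyrrolidin-1-yl in place of piperidin-1-yl on a thiocarbonyl carbon. Among the compounds with values here, no step between measured compounds isolates this change on its own. With compound 1 at 84.5% as the only measured pyrrolidin-1-yl case, a modest rise from compound 2 is expected, in the direction of compound 1, though it may not clear the scatter. The step is expected to be a number 7.9 percentage points higher from compound 2 to compound 3 (within the scatter) in this assay. Compound 3 is estimated at 77%, within a range of 62% to 90%.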

Compound 3, percent growth inhibition at one concentration: 86.4%
Compound 3: middle estimate off by 9.4 percentage points, on the low side, and the stated range covers the measured number.
By their numbers in this assay, from the lowest: compound 2; then compounds 1 and 3 (each within the scatter of the next).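

Working notes on the series: in this assay, pyrrolidin-1-yl in place of piperidin-1-yl on a thiocarbonyl carbon now has a single-place reading (a number 17.3 percentage points higher from compound 2 to compound 3 (beyond the scatter)), which the two-place pair of compound 1 and compound 2 could not give. With pyrrolidin-1-yl held fixed, methyl in place of hydrogen on an aromatic carbon gives a step that stays inside the scatter (a number 1.9 percentage points higher from compound 1 to compound 3 (within the scatter)), so in this pair the methyl group shows no resolved effect on growth inhibition, and of the two changes separating compound 1 from compound 2, only the ring change has a step beyond the scatter. Nothing available here bears on why the ring change moves this read-out.

Going by these compounds alone, it remains open whether the methyl step would also stay within the scatter with piperidin-1-yl on the thiocarbonyl carbon, since both readings of that step so far rest on pyrrolidin-1-yl. Also open, going by these compounds, is how other groups would read at the same place, such as morpholin-4-yl, azepan-1-yl or an open-chain dimethylamino group, and whether methoxy or chlorine in place of the methyl group would hold the reading of compound 3.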